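A few compounds are considered here, and "the series" means these few. Any claim that something is new, unique, unknown or untested is made for them only; others in the source may bear on it.

Compound 1, with the structure `CCN(C)c1nc(Cc2c(F)cccc2F)c(C)c(=O)[nH]1`, compound 2, with the structure `Cc1c(Cc2c(F)cccc2F)nc(N(C)C(C)C)[nH]c1=O`, and compound 3, with the structure `Cc1c(C(C)c2c(F)cccc2F)nc(N(C)C)[nH]c1=O`, were each examined in an ADME assay on MT4 cells (Homo sapiens) for cytotoxicity, read by MTT assay, with a stated time of 4 days; a higher number here means that more compound is tolerated, a lower number that less compound is tolerated. For compound 1 the result is a limit of the assay, > 85000 nM, so that only a floor is known; this is the limit described by the limit of > 85000 nM in this assay, at which 1 of the 3 values shown sits. Compound 2 gives 79000 nM in this assay. For compound 3 the result is again a limit of the assay, > 17000 nM, corresponding to the limit of > 17000 nM in this assay, at which 1 of the 3 values shown sits.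

Compound 1 and compound 2 differ by methyl in place of hydrogen on a saturated chain carbon bound to a nitrogen on an aromatic ring and a saturated chain carbon, and this change produced an at least 1.0-fold lower number from compound 1 to compound 2 (0.03 log units; that floor lies within the scatter), a step that lies within the scatter. Compound 3 shares its atoms with compound 1 but joins them differently; the difference between the two cores is not broken down here.

Compound 4, with the structure `CCc1c(C(C)c2c(F)cccc2F)nc(N(C)C)[nH]c1=O`, has not yet been measured in this assay. It differs from compound 3 by methyl in place of hydrogen on a saturated chain carbon bound to an aromatic carbon. This is the same kind of change as that from compound 1 to compound 2, though the place differs: there the carbon is bound to a nitrogen on an aromatic ring and a saturated chain carbon, here it is bound to an aromatic carbon. Since compound 3 only reached > 17000 nM and the earlier step of an at least 1.0-fold lower number from compound 1 to compound 2 (0.03 log units; that floor lies within the scatter) was small, a step that the limit leaves unreadable from compound 3 to compound 4 is expected. Compound 4 is therefore estimated to give about 40000 nM in this assay, between 15000 nM and 100000 nM, with a fair chance that only a limit is reported.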

Compound 4, half-maximal cytotoxic concentration: > 81000 nM
Compound 4 gave a limit, no number (the forecaster's own chance of this, stated with the estimate: 55%); middle value at least 2.0-fold (0.30 log units) from the limit.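

In this assay compound 3 and compound 4 both gave only limits of the assay and no numbers, so the step between them cannot be read. The compounds shown leave open whether methyl in place of hydrogen on a saturated chain carbon bound to an aromatic carbon changes the result in this assay at all, and by how much.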